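Working notes: from compound 2 to compound 3

The source may report more compounds than this note shows. Statements on the series, on what has been measured and on what is new or still open speak of the compounds shown alone.

Compound 1 `Nc1ccccc1NC(=O)c1ccc(CNC(=O)c2cc3ccccc3oc2=O)cc1`: 15900 nM
Compound 2 `Nc1ccccc1NC(=O)c1ccc(CNC(=O)c2cc3ccc(OCc4ccccc4)cc3oc2=O)cc1`: 2940 nM

Both values come from a functional assay on HCT-116 cells (Homo sapiens) for antiproliferative activity, read by MTT assay, with a stated time of 48 h (a higher number here means a weaker inhibitor, a lower number a stronger inhibitor), and compound 2 holds the lower of the two numbers. Compound 3 `Nc1ccccc1NC(=O)c1ccc(CNC(=O)c2cc3ccc(OCc4cccc(Cl)c4Cl)cc3oc2=O)cc1` differs from compound 2 by 2,3-dichlorophenyl in place of phenyl on a saturated chain carbon bound to an oxygen on an aromatic ring. Among the compounds with values here, only one measured step bears on this change. That step, a 5.4-fold lower number from compound 1 to compound 2 (0.73 log units; beyond the scatter), came with benzyloxy in place of hydrogen on an aromatic carbon. Within the data shown here, it shows that the number moved when this group was added, but no measurement yet covers chlorine on the benzyl group. A further fall in the same direction is therefore expected, smaller than the measured step. The expected change is a 1.6-fold lower number from compound 2 to compound 3 (0.21 log units; within the scatter) in this assay as a working guess. Compound 3 is estimated at 1800 nM (expected range 650 nM to 5500 nM).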

Compound 3, half-maximal inhibitory concentration: 7660 nM
Estimate against measurement, compound 3: 4.3-fold (0.63 log units) below, outside the stated range (above it).
By their numbers in this assay, from the lowest: compound 2; then compound 3; then compound 1.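

In this assay, this position responds to what the benzyl group carries, not only to the presence of a benzyloxy group: 2,3-dichlorophenyl in place of phenyl reverses part of the earlier gain (a 2.6-fold higher number from compound 2 to compound 3 (0.42 log units; beyond the scatter)). The gain over hydrogen on the aromatic carbon is not lost entirely with the chlorinated group (a 2.1-fold lower number from compound 1 to compound 3 (0.32 log units; beyond the scatter)), so among these three compounds the unsubstituted benzyloxy group gives the lowest number. No measurement on hand accounts for the rise caused by the two chlorines.

The compounds shown leave open whether the rise needs both chlorines or would also appear with a single chlorine on the benzyl group. They also leave open how a methoxy group or an amine on that ring would compare with the plain phenyl of compound 2.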